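Half-life across three substituents on one ring nitrogen

This account rests on a few compounds, and the source may have more. Where it says the series, first, only, none or still open, it means among the compounds named here.

Compound 1 `O=C1N(c2ccncc2)CCN1c1cccc2c1cnn2-c1ccccc1F`: 1.3 h
Compound 2 `O=C1N(Cc2ncco2)CCN1c1cccc2c1cnn2-c1ccccc1F`: 1.1 h

In an ADME assay on the whole organism (strain Sprague-Dawley) for metabolic stability, with Rattus norvegicus as the target, read by LC-MS (a higher number here means that the compound lasts longer, a lower number that the compound disappears faster), compound 2 gives 1.1 h, which lies within the scatter of compound 1 at 1.3 h. The next structure to be measured is compound 3 `CC(C)(C)OC(=O)N1CCN(c2cccc3c2cnn3-c2ccccc2F)C1=O`, which carries tert-butoxycarbonyl in place of (1,3-oxazol-2-yl)methyl on an amide-type nitrogen in a ring.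

Going by the values given here, only one measured step bears on this change, and it involves the same kind of nitrogen. That step is a 1.2-fold lower number from compound 1 to compound 2 (0.07 log units; within the scatter), a swap of pyridin-4-yl for (1,3-oxazol-2-yl)methyl, and it stays within the scatter. Among the compounds with values here, no measured compound carries tert-butoxycarbonyl, so the data give no direct guide to this group, and no step beyond the scatter is expected in this assay. The expected step is a 1.1-fold lower number from compound 2 to compound 3 (0.04 log units; within the scatter). For compound 3 the estimated half-life is 1 h, with an expected range of 0.4 h to 2.5 h.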

Compound 3, half-life: 2 h
For compound 3 the middle estimate is 2.0-fold (0.30 log units) below the measured one; low and high end bracket the measured number.
By their numbers in this assay, from the lowest: compounds 2, 1 and 3 (each within the scatter of the next).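

In this assay, putting tert-butoxycarbonyl on the amide-type nitrogen in the ring gives a 1.8-fold higher number from compound 2 to compound 3 (0.26 log units; within the scatter) and a 1.5-fold higher number from compound 1 to compound 3 (0.19 log units; within the scatter) and neither step separates the new group from the two earlier ones. Compounds 1 and 2 both carry an aromatic ring in this substituent, whereas the tert-butoxycarbonyl of compound 3 has no ring, and the half-life of the three compounds still stays within the scatter. No measurement shown here offers an explanation for these half-lives.

The compounds shown leave open whether any group on this nitrogen can move the half-life beyond the scatter. On these data alone, a plain methyl, an amine-bearing chain or a carboxylic acid in this place remains untested in the data at hand, so the limits of this flat pattern stay unknown.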